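Sulfonamide series: shorter chain, bromine removed

The source may hold more compounds than are shown below. What is called first, only, known or untested is meant among the compounds shown, and "the series" means these compounds.

Two compounds of the series have numbers in a functional assay on ASPC1 cells (Homo sapiens) for inhibition, read by MTT assay, with a stated time of 72 h; a lower number here means a stronger inhibitor of growth, a higher number a weaker inhibitor of growth. Compound 1 `O=S(=O)(NCCCCNCc1ccc(Br)cc1)c1cc(C(F)(F)F)cc(C(F)(F)F)c1` gives 2900 nM in this assay. Compound 2 `O=S(=O)(NCCCNCc1ccc(C(F)(F)F)cc1)c1cc(C(F)(F)F)cc(C(F)(F)F)c1` gives 2000 nM in this assay. Compound 1 has the highest of the two numbers, but compound 2 lies within the scatter of it, so nothing about order can be read from the pair. Among the compounds with values here, no two measured compounds differ in a single place, so no step of known size is available.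

Compound 3 `O=S(=O)(NCCCNCc1ccccc1)c1cc(C(F)(F)F)cc(C(F)(F)F)c1` is not yet measured. Against compound 1 it shows (benzylamino in place of ((4-bromobenzyl)amino)methyl on a saturated chain carbon, three bonds along the chain from a sulfonamide nitrogen). The bromine is gone and the chain from the sulfonamide nitrogen to the aromatic ring is shorter. Neither change is mirrored anywhere among the measured compounds, so its effect has to be guessed. The expectation in this assay is a modest step toward a higher number, a weaker inhibitor of growth, with a step inside the scatter fully possible. For compound 3 the estimate is 4500 nM, within a range from 2000 nM to 10000 nM. The step this estimate implies, a 1.6-fold higher number from compound 1 to compound 3 (0.19 log units; within the scatter), is expected rather than measured.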

Compound 3, concentration for 50% growth inhibition: 13000 nM
For compound 3 the middle estimate is 2.9-fold (0.46 log units) below the measured one; measured number outside the range, above it.
By their numbers in this assay, from the lowest: compounds 2 and 1 (each within the scatter of the next); then compound 3.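

In this assay, within the data shown here, hydrogen in place of trifluoromethyl on an aromatic carbon gives a 6.5-fold higher number from compound 2 to compound 3 (0.81 log units; beyond the scatter), the first single-place reading, and it shows that this aromatic carbon is not indifferent to what it carries. Benzylamino in place of ((4-bromobenzyl)amino)methyl on a saturated chain carbon, three bonds along the chain from a sulfonamide nitrogen, gives a 4.5-fold higher number from compound 1 to compound 3 (0.65 log units; beyond the scatter), so both steps end at the same weaker inhibitor of growth, the only one of the three whose benzyl ring carries no further group. Nothing measured on these compounds speaks to the reason for this loss.

The second step changes both the chain and the bromine, so the share of each cannot be separated without a compound that has the longer chain and an unsubstituted ring. Going by these compounds, it also remains open whether other groups on the same aromatic carbon, such as chlorine, methoxy or a nitrile, keep the number close to that of the trifluoromethyl compound or fall toward that of the unsubstituted one.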